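This account rests on a few compounds, and the source may have more. Where it says the series, first, only, none or still open, it means among the compounds named here.

Compounds measured in a functional assay on CHO cells for agonist activity at Alpha-1A adrenergic receptor (Homo sapiens), read by FLIPR and calcium flux; on this read-out lower numbers stand for an effect already at smaller amounts and higher numbers for an effect only at larger amounts of compound:
compound 1, `CCCS(=O)(=O)Nc1cccc2c1CCC2c1ncc[nH]1`: 1340 nM
compound 2, `COc1cccc2c1CCC2c1ncc[nH]1`: 32 nM
compound 3, `CCS(=O)(=O)Nc1cccc(Cc2c[nH]cn2)c1`: 9 nM

Compound 1 stands highest of the three numbers in this assay; the nearest is compound 2 and the furthest is compound 3, both gaps beyond the scatter. The change from compound 1 to compound 4, `c1cncc(-c2cccc3c2CCC3c2ncc[nH]2)c1`, is pyridin-3-yl in place of (propylsulfonyl)amino on an aromatic carbon. Among the compounds with values here, the only measured step at the same place is a 42-fold lower number from compound 1 to compound 2 (1.62 log units; beyond the scatter), a large gain once the (propylsulfonyl)amino group was gone. Within the data shown here, compound 3, with an ethylsulfonylamino group on a different core, gives 9 nM, so a sulfonamide by itself does not force a high number; on the shared core of compound 1 and compound 2, however, the one exchange tried at this carbon paid off strongly. Among the measured compounds shown here, a pyridin-3-yl is not a methoxy, and no measured pair shows an aromatic ring entering here, so the size of any gain is uncertain and the range is set wide. The expected step is an 8.9-fold lower number from compound 1 to compound 4 (0.95 log units; beyond the scatter), toward a lower number. Compound 4 is estimated at 150 nM in this assay, with a range from 25 nM to 900 nM.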

Compound 4, half-maximal effective concentration: 2060 nM
Beside the measured number, compound 4's estimate is 14-fold (1.14 log units) below it; measured number above the stated range.
By their numbers in this assay, from the lowest: compound 3; then compound 2; then compounds 1 and 4 (each within the scatter of the next).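

In this assay, the exchange on this aromatic carbon gives a 1.5-fold higher number from compound 1 to compound 4 (0.19 log units; within the scatter), so losing the (propylsulfonyl)amino group does not by itself bring the low number seen with methoxy on the shared core. What matters at this carbon is therefore the group that enters, not only the group that leaves: two very different substituents, (propylsulfonyl)amino and pyridin-3-yl, now sit within the scatter of each other, while methoxy stands well apart from both. The direct comparison of the two replacements, a 64-fold higher number from compound 2 to compound 4 (1.81 log units; beyond the scatter), is as large as the step seen earlier from the sulfonamide to methoxy, and nothing available here accounts for the difference between methoxy and pyridin-3-yl. Still open, going by these compounds, is whether an ethoxy, a hydroxyl or an amine on this carbon would stay with methoxy or fall with the other two groups, and whether a plain phenyl ring would match pyridin-3-yl, which would show if the ring nitrogen has any bearing on the number. Also open, on these data alone, is whether methoxy or pyridin-3-yl would give the same steps on the core of compound 3.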